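The source may report more compounds than this note shows. Statements on the series, on what has been measured and on what is new or still open speak of the compounds shown alone.

Three compounds share one core and differ only in the aromatic group carried on a single carbon of that core. Compound 1 `c1csc(-c2noc(-c3ccc(C4=NCCN4)cc3)n2)c1` gives 1570 nM in an assay for inhibition of Amine oxidase [flavin-containing] A (Homo sapiens), read by fluorescence and spectrophotometry, using microsomes, with stated times of 30 min and 20 min; on this read-out lower numbers stand for stronger inhibition and higher numbers for weaker inhibition. Compound 2 `Clc1ccccc1-c1noc(-c2ccc(C3=NCCN3)cc2)n1` gives 17100 nM in this assay, and compound 3 `COc1cccc(-c2noc(-c3ccc(C4=NCCN4)cc3)n2)c1` gives 12000 nM in this assay. Compound 3 thus stands second highest of the three numbers: its nearest neighbour is compound 2, with a 1.4-fold lower number from compound 2 to compound 3 (0.15 log units; within the scatter), and its furthest is compound 1, with a 7.6-fold higher number from compound 1 to compound 3 (0.88 log units; beyond the scatter). Compound 4 `Clc1ccc(-c2noc(-c3ccc(C4=NCCN4)cc3)n2)cc1Cl` has not yet been measured; it differs from compound 3 by 3,4-dichlorophenyl in place of 3-methoxyphenyl on an aromatic carbon. Among the compounds with values here, two measured steps bear on this change. The replacement of thiophen-2-yl by a phenyl carrying one chlorine gave an 11-fold higher number from compound 1 to compound 2 (1.04 log units; beyond the scatter), and the replacement of that chlorophenyl by 3-methoxyphenyl gave a 1.4-fold lower number from compound 2 to compound 3 (0.15 log units; within the scatter), so an exchange between a chlorine-bearing phenyl and a methoxy-bearing phenyl has so far moved the number little. A second chlorine on the phenyl ring has no precedent among these compounds. Compound 4 is therefore expected to show a 1.2-fold higher number from compound 3 to compound 4 (0.07 log units; within the scatter), a step of no size beyond the scatter. Compound 4 is estimated at 14000 nM in this assay, within a range of 5000 nM to 40000 nM.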

Compound 4, half-maximal inhibitory concentration: 1110 nM
Beside the measured number, compound 4's estimate is 13-fold (1.10 log units) above it; measured number below the stated range.
By their numbers in this assay, from the lowest: compounds 4 and 1 (each within the scatter of the next); then compounds 3 and 2 (each within the scatter of the next).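

In this assay, the phenyl groups on this aromatic carbon turn out not to be interchangeable: 3,4-dichlorophenyl in place of 3-methoxyphenyl gives an 11-fold lower number from compound 3 to compound 4 (1.03 log units; beyond the scatter) and in place of 2-chlorophenyl gives a 15-fold lower number from compound 2 to compound 4 (1.19 log units; beyond the scatter) even though the exchange between those two singly substituted phenyl groups had stayed within the scatter. A phenyl group at this position also need not give a higher number than thiophen-2-yl, as 3,4-dichlorophenyl in place of thiophen-2-yl gives a 1.4-fold lower number from compound 1 to compound 4 (0.15 log units; within the scatter) and this step lies within the scatter, so the rise seen with compound 2 and compound 3 does not extend to compound 4. No measurement available here accounts for the size of these steps.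

The compounds shown leave open whether both chlorines of compound 4 are needed, since no phenyl group here carries a single chlorine at either of the two ring carbons that bear chlorine in compound 4. They also leave open how bromine, methyl, trifluoromethyl, an amine or a carboxylic acid at those ring carbons would compare with chlorine.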